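Swapping a phenyl for a fluoro on a weak inhibitor

The source may report more compounds than this note shows. Statements on the series, on what has been measured and on what is new or still open speak of the compounds shown alone.

Of the compounds shown here, three sharing one core have been tested in an assay on isolated protein for inhibition of Indoleamine 2,3-dioxygenase 1 (Homo sapiens), read by spectrophotometry; on this read-out lower numbers stand for stronger inhibition and higher numbers for weaker inhibition. Compound 1 `O=C(Cc1cccnc1)c1cc2cc(-c3ccccc3)ccc2[nH]1` gives 96000 nM. Compound 2 `Cn1c(C(=O)Cc2cccnc2)cc2ccccc21` gives 34000 nM, and compound 3 `COc1ccc2[nH]c(C(=O)Cc3cccnc3)cc2c1O` gives 63000 nM. Compound 1 thus has the highest of the three numbers, but its gap to compound 3 lies within the scatter of repeated measurements, so those two cannot be told apart; only compound 2 stands clearly lower than compound 1, and all three are weak inhibitors on this scale.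

Compound 4 `O=C(Cc1cccnc1)c1cc2cc(F)ccc2[nH]1` has not yet been measured in this assay. It differs from compound 1 in one place: fluoro in place of phenyl on an aromatic carbon. Going by the values given here, no measured pair shows what such a change does here, so the expectation rests on the weak level of compound 1 alone. The step from compound 1 to compound 4 is expected to be small, if anything toward a lower number, as a 1.6-fold lower number from compound 1 to compound 4 (0.20 log units; within the scatter). Compound 4 is therefore estimated at 60000 nM, with a likely range from 15000 nM to 250000 nM.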

Compound 4, half-maximal inhibitory concentration: 36000 nM
Estimate against measurement, compound 4: 1.7-fold (0.22 log units) above; low and high end bracket the measured number.
By their numbers in this assay, from the lowest: compounds 2, 4, 3 and 1 (each within the scatter of the next, the first and the last beyond it).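

Replacing the phenyl with a fluoro on this aromatic carbon gives a 2.7-fold lower number from compound 1 to compound 4 (0.43 log units; beyond the scatter) in this assay, so the number does respond to what sits at this position. The phenyl, a whole six-membered ring, can give way to a single fluorine atom without any loss of inhibition on this read-out. The gain is modest, though, and compound 4 at 36000 nM remains a weak inhibitor. Nothing available explains why the number falls with this change.

As far as these compounds go, it stays open whether the step comes from losing the phenyl or from gaining the fluoro. A plain hydrogen, a chloro or an amine on this same carbon could help separate the two, and could show whether this position offers anything beyond a small shift.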